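Working notes: methyl to hydrogen on the ring nitrogen, compound 2 to 4

The compounds below may be only part of what the source reports. "The series", "measured", "known", "first", "only" and "open" are said of these compounds alone.

Measured in an ADME assay on MT4 cells (Homo sapiens) for cytotoxicity, read by MTT assay, with a stated time of 96 h; on this read-out lower numbers stand for higher toxicity in this test and higher numbers for lower toxicity in this test:
compound 1 `Cn1c(-c2ccc(NC(=O)CN3CCCC3)cc2)nc2cc(C(F)(F)F)ccc21`: 16000 nM
compound 2 `Cn1c(-c2ccc(NC(=O)CN3CCN(c4ccccc4)CC3)cc2)nc2cc(C(F)(F)F)ccc21`: 1500 nM
compound 3 `Cn1c(-c2ccc(NC(=O)CN3CCCCC3)cc2)nc2cc(C(F)(F)F)ccc21`: 9000 nM

Compound 2 stands lowest of the three numbers, and both steps away from it, an 11-fold lower number from compound 1 to compound 2 (1.03 log units; beyond the scatter) and a 6.0-fold higher number from compound 2 to compound 3 (0.78 log units; beyond the scatter), are beyond the scatter; the remaining step, a 1.8-fold lower number from compound 1 to compound 3 (0.25 log units; within the scatter), is within it. Compound 4 `O=C(CN1CCN(c2ccccc2)CC1)Nc1ccc(-c2nc3cc(C(F)(F)F)ccc3[nH]2)cc1` differs from compound 2 by hydrogen in place of methyl on an aromatic nitrogen. Going by the values given here, none of the measured steps bears on this change: all three vary only the amine on the saturated chain carbon bound to a carbonyl carbon. Among the compounds with values here, with no measured step on the ring nitrogen, no step beyond the scatter is expected in this assay, so the estimated step is no change at the digits printed from compound 2 to compound 4 (within the scatter). Compound 4 is therefore expected to give about 1500 nM, in a range from 500 nM to 4500 nM.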

Compound 4, half-maximal cytotoxic concentration: 900 nM
Compound 4: the middle estimate sits 1.7-fold (0.22 log units) above what was measured; low and high end bracket the measured number.
By their numbers in this assay, from the lowest: compounds 4 and 2 (each within the scatter of the next); then compounds 3 and 1 (each within the scatter of the next).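

In this assay, going by these compounds alone, the first step at the ring nitrogen, hydrogen in place of methyl on an aromatic nitrogen, gives a 1.7-fold lower number from compound 2 to compound 4 (0.22 log units; within the scatter). Unlike the amine changes, which moved the number beyond the scatter in two of three steps, this change stays within it, so with 4-phenylpiperazin-1-yl held in place the methyl is not required for this read-out. No supporting data on the cause of this result are available.

On these data alone, whether the same holds with pyrrolidin-1-yl or piperidin-1-yl in place of 4-phenylpiperazin-1-yl remains open. So does the reading of a larger group on this nitrogen, such as ethyl or benzyl.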